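This account rests on a few compounds, and the source may have more. Where it says the series, first, only, none or still open, it means among the compounds named here.

Working notes on the series, read in a functional assay on HCT-116 cells (Homo sapiens) for cytotoxicity, read by MTT assay, with a stated time of 72 h; on this read-out lower numbers stand for stronger inhibition and higher numbers for weaker inhibition. Within the data shown here, compound 1 (`COc1ccc(C(=O)n2c(CC(C)C)nc3ccccc32)cc1`) gives 3560 nM and compound 2 (`COc1ccc(C(=O)n2c(C(C)C)nc3ccccc32)cc1`) gives 190 nM, so compound 2 holds the lower of the only two numbers so far. Next comes compound 3 (`COc1ccc(C(=O)n2c(C3CCCCC3)nc3ccccc32)cc1`), with cyclohexyl in place of isopropyl on an aromatic carbon. Among the measured compounds shown here, one measured step bears on this change, made on the same carbon: a 19-fold lower number from compound 1 to compound 2 (1.27 log units; beyond the scatter), with isopropyl in place of isobutyl. This single large step shows that the number can move far with the group held there, but it gives no trend. A higher number is expected for compound 3 in this assay, by a moderate step smaller than that one. The estimated value for compound 3 is 800 nM, within a range of 200 nM to 3500 nM. The expected change is a 4.2-fold higher number from compound 2 to compound 3 (0.62 log units; beyond the scatter).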

Compound 3, half-maximal inhibitory concentration: > 10000 nM
Compound 3 gave a limit, no number; the forecaster's own chance of this, stated with the estimate: 3%; middle value at least 12-fold (1.09 log units) away from the limit.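

Compound 3 gives a limit of the assay and not a number: the limit of > 10000 nM in this assay, at which 1 of the 3 values shown sits.

Read against that limit, the change from isopropyl to cyclohexyl is an at least 52-fold higher number from compound 2 to compound 3 (1.72 log units; beyond the scatter), and the change from isobutyl to cyclohexyl is an at least 2.8-fold higher number from compound 1 to compound 3 (0.44 log units; beyond the scatter). Among the three groups on this aromatic carbon, isopropyl therefore gives the lowest number, and both the open chain of isobutyl and the ring of cyclohexyl give higher ones, so the earlier single step now has a second departure from isopropyl beside it.

Going by these compounds, whether a methyl, an ethyl or a cyclopropyl ring on this carbon would match or lower the number of compound 2 stays open. So does whether an amine on the cyclohexyl ring would bring compound 3 back to a measurable value.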